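The source may report more compounds than this note shows. Statements on the series, on what has been measured and on what is new or still open speak of the compounds shown alone.

Among the compounds with values here, compound 2 `COc1ccc(CNC(=O)c2nn(-c3ccc(F)cc3)c(OC[C@@H](O)C[C@@H](O)CC(=O)O)c2C(C)C)cc1` holds the higher of the two numbers so far: in an assay on microsomes from liver for inhibition of 3-hydroxy-3-methylglutaryl-coenzyme A reductase (Rattus norvegicus) (a higher number here means a weaker inhibitor, a lower number a stronger inhibitor), compound 2 gives 12 nM, whereas compound 1 `CC(C)c1c(C(=O)NCc2cccc(F)c2F)nn(-c2ccc(F)cc2)c1OC[C@@H](O)C[C@@H](O)CC(=O)O` gives 2 nM. Within the data shown here, the single measured step is a 6.0-fold higher number from compound 1 to compound 2 (0.78 log units; beyond the scatter). Compound 3 `CC(C)c1c(C(=O)NCc2ccccc2Cl)nn(-c2ccc(F)cc2)c1OC[C@@H](O)C[C@@H](O)CC(=O)O` differs from compound 2 by 2-chlorophenyl in place of 4-methoxyphenyl on a saturated chain carbon bound to an amide-type nitrogen. The group that leaves is the one that entered with the step from compound 1, and a halogen-bearing ring comes back. In this assay compound 3 is therefore expected to show a modest move toward a lower number, about a 3.0-fold lower number from compound 2 to compound 3 (0.48 log units; beyond the scatter). The estimate for compound 3 in this assay is 4 nM, with a range from 1.5 nM to 12 nM.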

Compound 3, half-maximal inhibitory concentration: 9.5 nM
For compound 3 the middle estimate is 2.4-fold (0.38 log units) below the measured one; low and high end bracket the measured number.
By their numbers in this assay, from the lowest: compound 1; then compounds 3 and 2 (each within the scatter of the next).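

Going to 2-chlorophenyl gives a 1.3-fold lower number from compound 2 to compound 3 (0.10 log units; within the scatter) in this assay and a 4.8-fold higher number from compound 1 to compound 3 (0.68 log units; beyond the scatter) in the same assay series. A chlorine-bearing ring on this saturated chain carbon therefore does not return the number of compound 1, so a halogen alone is not enough here. Among these three compounds, only 2,3-difluorophenyl stands apart, while 2-chlorophenyl and 4-methoxyphenyl cannot be told apart.

Still open, from the compounds shown here alone, is whether both fluorines are needed, and how an unsubstituted phenyl or a pyridine ring would read at this place. Nothing available bears on the reason for this result.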